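Adding a Fluorine to the Phenyl Ring of Compound 2

The source may hold more compounds than are shown below. What is called first, only, known or untested is meant among the compounds shown, and "the series" means these compounds.

Compound 1 `[O-][S+](Cc1ccccc1)c1nnc(-c2ccncc2)o1` gives 3000 nM in a functional assay on HUVEC cells (Homo sapiens) for inhibition, read by ELISA; on this read-out lower numbers stand for stronger inhibition and higher numbers for weaker inhibition.
Compound 2 `COc1c(C)cnc(C[S+]([O-])c2nnc(-c3ccccc3)o2)c1C` gives 6000 nM in this assay.
Compound 3 `[O-][S+](Cc1ccccc1)c1nnc(-c2ccccc2O)o1` gives 6000 nM in this assay.

The three measured numbers sit close together. Compound 2 shows no change at the digits shown against compound 3, and the gap to compound 1 is within the usual scatter of repeated measurements. Among the measured compounds shown here, the only one-place step among the measured compounds, a 2.0-fold higher number from compound 1 to compound 3 (0.30 log units; within the scatter), is also within the scatter, and it concerns the ring on the far side of the shared core rather than the part touched here.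

Compound 4 `COc1c(C)cnc(C[S+]([O-])c2nnc(-c3ccc(F)cc3)o2)c1C` differs from compound 2 in one place: fluoro in place of hydrogen on an aromatic carbon. For the measured compounds named here, no measured pair differs by a fluoro group, so no step of this kind is available to weigh the change; the measured steps simply show that small changes around this core have so far stayed within the scatter. On that basis the step of no change at the digits printed from compound 2 to compound 4 (within the scatter) is expected to be no larger than the scatter. Compound 4 is therefore estimated at 6000 nM in this assay. The range for compound 4 is expected to run from 2500 nM to 15000 nM.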

Compound 4, half-maximal inhibitory concentration: 11000 nM
Beside the measured number, compound 4's estimate is 1.8-fold (0.26 log units) below it; the range from low to high includes it.
By their numbers in this assay, from the lowest: compounds 1, 2, 3 and 4 (each within the scatter of the next, the first and the last beyond it).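

In this assay, the change from phenyl to 4-fluorophenyl gives a 1.8-fold higher number from compound 2 to compound 4 (0.26 log units; within the scatter), so a fluoro group on this aromatic carbon, para to a large group, produces no shift that stands clear of the usual scatter. Among the compounds shown here, this is the first reading at this place on the ring of compound 2: the only earlier one-place step, a 2.0-fold higher number from compound 1 to compound 3 (0.30 log units; within the scatter), swapped one whole ring for another and carried no information about a fluoro group. Nothing available here explains the step or shows what the fluoro group does in these compounds, so the finding remains a comparison of measured numbers and nothing more.

Going by these compounds, a single small atom says little about how much room for change this carbon offers, so it remains open whether a larger or very different group, such as a methoxy group, an amine or a carboxylic acid, would move the number beyond the scatter. On these data alone, it also remains open whether a second fluoro group or a chloro group on the same ring would keep the number within the scatter of compound 2.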